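A few compounds are considered here, and "the series" means these few. Any claim that something is new, unique, unknown or untested is made for them only; others in the source may bear on it.

Measured so far in a functional assay on BXPC-3 cells (Homo sapiens) for inhibition, read by MTT assay, with a stated time of 72 h; a higher number here means a weaker inhibitor, a lower number a stronger inhibitor:

Compound 1 `O=C(Nc1cccc2cccnc12)c1ncccn1`; in this assay compound 1 gives > 10000 nM, a limit.
Compound 2 `COc1cc(NC(=O)c2ncccn2)c2ncccc2c1`; in this assay compound 2 gives > 10000 nM, a limit.
Compound 3 `Cc1cnc(C(=O)Nc2cc(OCCN)cc3cccnc23)cn1`; in this assay compound 3 gives > 10000 nM, a limit.

Compound 3 stands at the limit of this assay, as do the other two values (the limit of > 10000 nM in this assay, at which 3 of the 3 values shown sit). For the measured compounds named here, the one measured step, from compound 1 to compound 2, reads a step that the two limits leave unreadable from compound 1 to compound 2 and so gives no size.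

Compound 4 `NCCOc1cc(NC(=O)c2ncccn2)c2ncccc2c1` differs from compound 3 by pyrimidin-2-yl in place of 5-methylpyrazin-2-yl on a carbonyl carbon. Going by the values given here, no measured step bears on this change, and every value shown is a limit, so no direction beyond the scatter can be expected from the numbers.

Compound 4 is therefore expected to sit at the same limit, estimated at 15000 nM with a range of 5000 nM to 60000 nM. The step from compound 3 to compound 4 is expected as a step that the limit leaves unreadable from compound 3 to compound 4, meaning no change beyond the scatter.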

Compound 4, half-maximal inhibitory concentration: > 10000 nM
Compound 4: only a limit was reported; the forecaster's own chance of this, stated with the estimate: 80%; the middle value lies beyond the limit too.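

No step to compound 4 from compound 1, compound 2 or compound 3 can be read, as each value is a limit: the limit of > 10000 nM in this assay, at which 4 of the 4 values shown sit.

The compounds shown leave open whether any of these changes alters inhibition at all.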